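From iodo to nitro, guided by one measured step

The source may hold more compounds than are shown below. What is called first, only, known or untested is meant among the compounds shown, and "the series" means these compounds.

Within the data shown here, in a functional assay on CRL2813 cells (Homo sapiens) for cytotoxicity, read by sulforhodamine B assay, with a stated time of 5 days (a lower number here means a stronger inhibitor, a higher number a weaker inhibitor), compound 1 `O=C(Nc1ccc(I)cc1)N[C@H]1CC[C@H](Oc2ccc(F)cc2)CC1` gives 10200 nM, the highest of the two numbers known so far. Compound 2 `O=C(Nc1ccccc1[N+](=O)[O-])N[C@H]1CC[C@H](Oc2ccc(F)cc2)CC1` gives 3500 nM. The next compound to be measured, compound 3 `O=C(Nc1ccc([N+](=O)[O-])cc1)N[C@H]1CC[C@H](Oc2ccc(F)cc2)CC1`, keeps the core of compound 1 and changes one group: nitro in place of iodo on an aromatic carbon. Compound 3 thus carries 4-nitrophenyl where compound 1 carries 4-iodophenyl. Among the measured compounds shown here, only one measured step bears on this change: a 2.9-fold lower number from compound 1 to compound 2 (0.46 log units; beyond the scatter). That step also brings in a nitro group, but as 2-nitrophenyl, so it is only a loose guide to 4-nitrophenyl. For the measured compounds named here, a modest drop in this assay is therefore expected, probably no larger than that step. The estimated step is a 2.3-fold lower number from compound 1 to compound 3 (0.36 log units; beyond the scatter). For compound 3 the estimated value is 4500 nM, with an expected range from 1500 nM to 12000 nM.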

Compound 3, half-maximal inhibitory concentration: 2300 nM
For compound 3 the middle estimate is 2.0-fold (0.29 log units) above the measured one, within the range that was stated.
By their numbers in this assay, from the lowest: compounds 3 and 2 (each within the scatter of the next); then compound 1.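

In this assay the direct exchange of iodo for nitro on this aromatic carbon, para to a large group, gives a 4.4-fold lower number from compound 1 to compound 3 (0.65 log units; beyond the scatter) so the lower number seen earlier with 2-nitrophenyl also appears with the nitro group at this position. Comparing the two nitro compounds gives a 1.5-fold lower number from compound 2 to compound 3 (0.18 log units; within the scatter) so 4-nitrophenyl and 2-nitrophenyl cannot be told apart in this assay, and the location of the nitro group on the ring shows no measurable effect here. No measurement available here explains why nitro gives a lower number than iodo.

On these data alone, whether this gain is particular to nitro remains open, since a nitrile, an amine or a carboxylic acid on the same aromatic carbon could give a quite different number. As far as these compounds go, it is also open whether the gain would persist with a group other than the 4-fluorophenoxy part of the core.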